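The source may hold more compounds than are shown below. What is called first, only, known or untested is meant among the compounds shown, and "the series" means these compounds.

Measured so far:
compound 1 `CC1(C)[C@H]2CC[C@]1(C)N(Cc1cn(-c3ccccc3Br)nn1)C(=O)C2` — 140 nM
compound 2 `CC1(C)[C@H]2CC[C@]1(C)N(Cc1cn(-c3ccc(O)cc3)nn1)C(=O)C2` — 410 nM

Going by the values given here, in a functional assay on OVCAR-3 cells (Homo sapiens) for inhibition, read by MTT assay, with a stated time of 24 h (on this read-out higher numbers stand for weaker inhibition and lower numbers for stronger inhibition), compound 2 gives the highest of the two numbers in hand; its nearest neighbour is compound 1, and the single step available, a 2.9-fold higher number from compound 1 to compound 2 (0.47 log units; beyond the scatter), separates them. Compound 3 `Cc1cccc(-n2cc(CN3C(=O)C[C@@H]4CC[C@@]3(C)C4(C)C)nn2)c1` is not yet measured. It differs from compound 2 in one place: 3-methylphenyl in place of 4-hydroxyphenyl on an aromatic nitrogen. Among the compounds with values here, the only measured step that bears on this change is the one from compound 1 to compound 2, which also exchanged the group on that aromatic nitrogen and gave a modest rise in the number. Since the new group of compound 3 again removes the 4-hydroxyphenyl that accompanied the higher number, the expected step is a 1.9-fold lower number from compound 2 to compound 3 (0.27 log units; within the scatter), a modest fall that would place compound 3 nearer to compound 1 than to compound 2, with the direction not secure on one step alone. The estimate for compound 3 in this assay is 220 nM, expected within 80 nM to 600 nM.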

Compound 3, half-maximal inhibitory concentration: 160 nM
Beside the measured number, compound 3's estimate is 1.4-fold (0.14 log units) above it, within the range that was stated.
By their numbers in this assay, from the lowest: compounds 1 and 3 (each within the scatter of the next); then compound 2.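

The step to 3-methylphenyl, a 2.6-fold lower number from compound 2 to compound 3 (0.41 log units; beyond the scatter), shows in this assay that the gap seen with 4-hydroxyphenyl is not specific to 2-bromophenyl: a second group on this aromatic nitrogen also gives a number lower than that of compound 2. Against 2-bromophenyl, a 1.1-fold higher number from compound 1 to compound 3 (0.06 log units; within the scatter) leaves the two groups indistinguishable on this read-out, although one carries bromine and the other a methyl. No measurement on hand gives a reason for these differences.

The compounds shown do not separate the effect of the hydroxyl from that of where a substituent sits on the phenyl ring, as the three groups differ in both. Also open, going by these compounds, is how an unsubstituted phenyl, an amine or a carboxylic acid on this ring would read against compound 1, compound 2 and compound 3.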